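The compounds below may be only part of what the source reports. "The series", "measured", "known", "first", "only" and "open" are said of these compounds alone.

Measured in a functional assay on HL-60 cells (Homo sapiens) for cytotoxicity, read by luminescence and CellTiter-Glo, with a stated time of 3 days; on this read-out lower numbers stand for stronger inhibition and higher numbers for weaker inhibition:
- compound 1 `O=C(Nc1ccc(C(F)(F)F)cc1)c1cc(Cl)c(-c2ccccc2)cc1O`: 490 nM
- compound 2 `O=C(Nc1ccc(C(F)(F)F)cc1)c1cc(Br)c(F)cc1O`: 450 nM
- compound 3 `O=C(Nc1ccc(C(F)(F)F)cc1)c1cc(Br)c(-c2ccccc2)cc1O`: 540 nM

The three values sit close together. Compound 3 gives 540 nM, which lies within the scatter of both compound 1 and compound 2, so no order among the three can be read from these numbers.

Compound 4 `N#Cc1ccc(NC(=O)c2cc(Br)c(-c3ccccc3)cc2O)cc1` differs from compound 3 in one place, with cyano in place of trifluoromethyl on an aromatic carbon, para to a large group: cyano in place of trifluoromethyl on an aromatic carbon.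

Among the compounds with values here, two measured steps bear on this only indirectly: a 1.1-fold higher number from compound 1 to compound 3 (0.04 log units; within the scatter) for bromo in place of chloro, and a 1.2-fold higher number from compound 2 to compound 3 (0.08 log units; within the scatter) for phenyl in place of fluoro. Both lie within the scatter, but neither touches the trifluoromethyl group, which all three measured compounds carry. Within the data shown here, the data therefore hold no measured step for this change, and the small size of those two steps says little about it.

A modest move toward a higher number, meaning weaker inhibition, is expected, although the direction remains uncertain. The expected change is a 1.5-fold higher number from compound 3 to compound 4 (0.17 log units; within the scatter). In this assay the estimate for compound 4 is 800 nM, with an expected range from 250 nM to 2500 nM.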

Compound 4, half-maximal inhibitory concentration: 700 nM
Compound 4: the middle estimate sits 1.1-fold (0.06 log units) above what was measured; the measured number falls inside the stated range.
By their numbers in this assay, from the lowest: compounds 2, 1, 3 and 4 (each within the scatter of the next).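

In this assay, within the data shown here, the change from trifluoromethyl to cyano, on an aromatic carbon para to a large group, gives a 1.3-fold higher number from compound 3 to compound 4 (0.11 log units; within the scatter) and so provides the first measured step at this position, since compound 1, compound 2 and compound 3 all carry trifluoromethyl there. The step lies within the scatter, so no order can be read between compound 3 and compound 4, even though the entering cyano has 2 heavy atoms where the leaving trifluoromethyl has 4, and it adds 1 hydrogen-bond acceptor where the leaving group has none. Nothing available accounts for the result or ties it to any property of either group.

The compounds shown leave open whether a group of a different kind on this carbon, such as an amine or a carboxylic acid, would move the number beyond the scatter. They also leave open whether cyano in place of trifluoromethyl would give a similarly small step with chloro in place of bromo, or with fluoro in place of phenyl, elsewhere on the shared core.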